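The source may hold more compounds than are shown below. What is called first, only, known or untested is meant among the compounds shown, and "the series" means these compounds.

Compound 1 `COc1cc(Cl)cc(-c2nn(-c3cccc(NC(=O)Nc4ccc(Cl)c(Cl)c4)c3)cc2-c2ccncc2)c1` and compound 2 `COc1cc(Cl)cc(-c2nn(-c3cccc(NC(=O)Nc4cccc(C(F)(F)F)c4)c3)cc2-c2ccncc2)c1` share one core and differ in the aryl group on the urea nitrogen. In a functional assay on CCRF-CEM cells (Homo sapiens) for inhibition, read by sulforhodamine B assay, with a stated time of 48 h, tested at 1 uM (a higher number here means a weaker effect of the compound at the concentration tested, a lower number a stronger effect), compound 1 gives 82%, and compound 2 gives 56%, the lowest of the two numbers; the step of a number 26 percentage points lower from compound 1 to compound 2 (beyond the scatter) is the only measured one. Compound 3 `COc1cc(Cl)cc(-c2nn(-c3cccc(NC(=O)c4cccc(C(F)(F)F)c4)c3)cc2-c2ccncc2)c1` differs from compound 2 as follows: 3-(trifluoromethyl)phenyl in place of (3-(trifluoromethyl)phenyl)amino on a carbonyl carbon. Within the data shown here, no measured step touches this linker change, so no clear guide exists, and the expected step of a number 9 percentage points higher from compound 2 to compound 3 (within the scatter) is small and uncertain. The estimate for compound 3 in this assay is 65%, within 40% to 90%.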

Compound 3, a percentage reported as activity, at one concentration (the size of the read-out at that concentration, not a potency): 53%
Compound 3: the middle estimate sits 12 percentage points above what was measured; the range from low to high includes it.
By their numbers in this assay, from the lowest: compounds 3 and 2 (each within the scatter of the next); then compound 1.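

In this assay, replacing (3-(trifluoromethyl)phenyl)amino with 3-(trifluoromethyl)phenyl on the carbonyl carbon removes the urea nitrogen and its hydrogen-bond donor, yet gives a number 3 percentage points lower from compound 2 to compound 3 (within the scatter), so this read-out does not separate the amide from the urea. Set against the 3,4-dichlorophenyl urea, the amide gives a number 29 percentage points lower from compound 1 to compound 3 (beyond the scatter), so the gap seen with the urea remains. Still open, from the compounds shown here alone, is how an amine or a carboxylic acid on the phenyl ring at this carbonyl carbon would behave. Nothing measured here explains these numbers.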